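Aryl variation on the fused core of the series

The source may report more compounds than this note shows. Statements on the series, on what has been measured and on what is new or still open speak of the compounds shown alone.

Measured compounds:
compound 1 `C=C(Br)C(=O)Nc1cccc(-c2cn3nc(Cc4ccccc4)sc3n2)c1` — 3000 nM
compound 2 `C=C(Br)C(=O)Nc1cccc(-c2cn3nc(Cc4ccc(Cl)cc4)sc3n2)c1` — 1100 nM
compound 3 `C=C(Br)C(=O)Nc1cccc(-c2cn3nc(-c4ccc(C)cc4)sc3n2)c1` — 1200 nM

In a functional assay on FM3A cells (Mus musculus) for inhibition, read by cell counting, with a stated time of 2 days (a higher number here means a weaker inhibitor, a lower number a stronger inhibitor), compound 3 stands second highest of the three numbers. Its nearest neighbour is compound 2, which lies within the scatter of it; compound 1 is furthest, with a 2.5-fold lower number from compound 1 to compound 3 (0.40 log units; beyond the scatter). The next compound is compound 4 `C=C(Br)C(=O)Nc1cccc(-c2cn3nc(-c4cccc(OC)c4)sc3n2)c1`, which differs from compound 3 by 3-methoxyphenyl in place of 4-methylphenyl on an aromatic carbon. Among the compounds with values here, no measured step exchanges one substituent for another on a phenyl group directly attached at this position. Step a 2.7-fold lower number from compound 1 to compound 2 (0.44 log units; beyond the scatter) and step a 2.5-fold lower number from compound 1 to compound 3 (0.40 log units; beyond the scatter) both start from the benzyl compound, and a 1.1-fold higher number from compound 2 to compound 3 (0.04 log units; within the scatter) shows that two different aryl substitutions give numbers within the scatter. Hence no step beyond the scatter is expected in this assay for compound 4, estimated at 1300 nM with a range of 500 nM to 3500 nM, i.e. a 1.1-fold higher number from compound 3 to compound 4 (0.03 log units; within the scatter).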

Compound 4, half-maximal inhibitory concentration: 500 nM
For compound 4 the middle estimate is 2.6-fold (0.41 log units) above the measured one, within the range that was stated.
By their numbers in this assay, from the lowest: compound 4; then compounds 2 and 3 (each within the scatter of the next); then compound 1.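

In this assay, within the data shown here, the aryl group directly attached at this position is not neutral: with a 2.4-fold lower number from compound 3 to compound 4 (0.38 log units; beyond the scatter) as the first exchange between two directly attached phenyl groups, 3-methoxyphenyl reads better than 4-methylphenyl. Compound 4 is the strongest of the four, with a 2.2-fold lower number from compound 2 to compound 4 (0.34 log units; beyond the scatter) and a 6.0-fold lower number from compound 1 to compound 4 (0.78 log units; beyond the scatter) as its steps from the benzyl compounds. No available evidence accounts for this gain.

Still open, as far as these compounds go, is whether the step follows from the methoxy group itself or from its place on the phenyl ring. Also open, from the compounds shown here alone, is how an amine or carboxylic acid on that ring would read.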